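This account rests on a few compounds, and the source may have more. Where it says the series, first, only, none or still open, it means among the compounds named here.

Measured compounds in a functional assay for agonist activity at Free fatty acid receptor 1 (Homo sapiens), read by FLIPR, in the presence of a further agent that is not named here; on this read-out higher numbers stand for an effect only at larger amounts of compound and lower numbers for an effect already at smaller amounts:
compound 1 `Cc1ccnc(Oc2ccc(CC3SC(=O)NC3=O)cc2)c1` gives 4280 nM
compound 2 `Cc1ccccc1Oc1ccc(CC2SC(=O)NC2=O)cc1` gives 124 nM
compound 3 `Cc1ccc(Oc2ccc(CC3SC(=O)NC3=O)cc2)cc1` gives 547 nM

Compound 3 holds the second highest number of the three. Its nearest neighbour is compound 2, reached by a 4.4-fold higher number from compound 2 to compound 3 (0.64 log units; beyond the scatter); its furthest is compound 1, separated by a 7.8-fold lower number from compound 1 to compound 3 (0.89 log units; beyond the scatter). The unmeasured compound 4 `Cc1ccc(Oc2ccc(CC3SC(=O)NC3=O)cc2)nc1` differs from compound 3 in one place: 5-methylpyridin-2-yl in place of 4-methylphenyl on an oxygen on an aromatic ring. For the measured compounds named here, the step that bears on it is the one from compound 1 to compound 3, where a methylphenyl group took the place of a methylpyridinyl group and the number fell by a 7.8-fold lower number from compound 1 to compound 3 (0.89 log units; beyond the scatter). Compound 4 runs that exchange backwards, though the entering group is 5-methylpyridin-2-yl rather than the 4-methylpyridin-2-yl of compound 1. The step of a 4.4-fold higher number from compound 2 to compound 3 (0.64 log units; beyond the scatter) shows that moving the methyl alone can shift the number by a modest amount, so the reverse of a 7.8-fold lower number from compound 1 to compound 3 (0.89 log units; beyond the scatter) is expected only roughly. A higher number beyond the scatter is expected in this assay. Compound 4 is expected to give about 3000 nM, within 1000 nM to 9000 nM. That corresponds to an expected step of a 5.5-fold higher number from compound 3 to compound 4 (0.74 log units; beyond the scatter).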

Compound 4, half-maximal effective concentration: 4470 nM
For compound 4 the middle estimate is 1.5-fold (0.17 log units) below the measured one; the range from low to high includes it.
By their numbers in this assay, from the lowest: compound 2; then compound 3; then compounds 1 and 4 (each within the scatter of the next).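

Swapping 4-methylphenyl for 5-methylpyridin-2-yl on the oxygen gives an 8.2-fold higher number from compound 3 to compound 4 (0.91 log units; beyond the scatter) in this assay, so the higher number seen with a pyridine at this position is not tied to the 4-methylpyridin-2-yl group of compound 1. The larger contrast, a 36-fold higher number from compound 2 to compound 4 (1.56 log units; beyond the scatter), sets this pyridine against the 2-methylphenyl group. The two methylpyridinyl isomers cannot be told apart, with a 1.0-fold higher number from compound 1 to compound 4 (0.02 log units; within the scatter), whereas the two methylphenyl isomers differ by a 4.4-fold higher number from compound 2 to compound 3 (0.64 log units; beyond the scatter), so a methyl shift moves the number among the phenyl compounds but not between these two pyridines.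

Open, on these data alone, is whether a 3-methylpyridin-2-yl group, or a pyrimidin-2-yl ring with a methyl group, would behave like these pyridines or like the 2-methylphenyl of compound 2. Nothing available explains why the ring nitrogen accompanies the higher numbers.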